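Compound 4: fused azole in place of the chlorophenyl

The source may hold more compounds than are shown below. What is called first, only, known or untested is meant among the compounds shown, and "the series" means these compounds.

In an ADME assay (liver) for metabolic stability, with Liver microsome (Homo sapiens) as the target, using microsomes (a higher number here means that the compound lasts longer, a lower number that the compound disappears faster), compound 1 `CCc1nc2cc(Cl)ccn2c1C(=O)NCc1ccc(-c2ccc(Cl)cc2)cc1` gives > 2 h, a limit of the assay and not a number. Compound 2 `CCc1nc2cc(Cl)ccn2c1C(=O)NCc1ccc(N2CCN(C(C)C)CC2)cc1` also gives > 2 h, again a limit. Compound 3 `CCc1nc2cc(Cl)ccn2c1C(=O)NCc1ccc(N2CC3CCCCC3C2)cc1` gives 0.248 h. Compound 1 therefore stands at the limit of > 2 h in this assay, at which 2 of the 3 values shown sit, the top of what this set can read; only compound 3 is clearly lower, with an at least 8.0-fold lower number from compound 1 to compound 3 (0.90 log units; beyond the scatter) and an at least 8.0-fold lower number from compound 2 to compound 3 (0.90 log units; beyond the scatter). Between compound 1 and compound 2 the step is a step that the two limits leave unreadable from compound 1 to compound 2.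

Compound 4 `CCc1nc2cc(Cl)ccn2c1C(=O)NCc1ccc(-n2cc3c(c2)CCCC3)cc1` differs from compound 1 by a group of 9 heavy atoms (8 carbon, 1 nitrogen; one five-membered aromatic ring with 1 hetero atom, one six-membered non-aromatic ring of carbon only) in place of a group of 7 heavy atoms (6 carbon, 1 chlorine; one six-membered aromatic ring of carbon only), on an aromatic carbon. Within the data shown here, the closest measured step is the one to compound 3, which also brings in a six-membered non-aromatic ring of carbon only and is an at least 8.0-fold lower number from compound 1 to compound 3 (0.90 log units; beyond the scatter); compound 4 instead carries a five-membered aromatic ring with 1 hetero atom. A drop is expected, an at least 3.3-fold lower number from compound 1 to compound 4 (0.52 log units; beyond the scatter), its size uncertain because compound 1 sits at the limit of > 2 h in this assay, at which 2 of the 3 values shown sit. Compound 4 is expected to give about 0.6 h, within 0.2 h to 2 h.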

Compound 4, half-life: 0.455 h
Compound 4: the middle estimate sits 1.3-fold (0.12 log units) above what was measured; low and high end bracket the measured number.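

Two compounds carrying a six-membered non-aromatic ring of carbon only now fall short of the limit compounds at this position, para to a large group, and compound 4 adds an at least 4.3-fold lower number from compound 1 to compound 4 (0.64 log units; beyond the scatter) and an at least 4.3-fold lower number from compound 2 to compound 4 (0.64 log units; beyond the scatter). Making the five-membered ring aromatic does not separate the two fused groups, with a 1.8-fold higher number from compound 3 to compound 4 (0.26 log units; within the scatter), so the low values in this assay do not depend on that ring being non-aromatic. Both drops from the limit compounds give only a minimum size: the limit of > 2 h in this assay, at which 2 of the 4 values shown sit.

From the compounds shown here alone, whether a plain pyrrol-1-yl or piperidin-1-yl group, without the six-membered carbon ring, would stay at the limit remains open. Going by these compounds, how compound 1 and compound 2 compare also stays open, since a step between two limits cannot be read.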